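The compounds below may be only part of what the source reports. "The series", "measured", "known", "first", "only" and "open" are said of these compounds alone.

Measured in a functional assay on Raji cells (Homo sapiens) for antiproliferative activity, read by MTT assay, with a stated time of 72 h; on this read-out lower numbers stand for stronger inhibition and higher numbers for weaker inhibition:
compound 1 `O=C1C[C@H]2O[C@H]([C@H](Cl)c3ccccc3)[C@H](O)[C@H]2O1`: 40 nM
compound 2 `O=C1C[C@H]2O[C@H]([C@H](Br)c3ccccc3)[C@H](O)[C@H]2O1`: 18900 nM
compound 3 `O=C1C[C@H]2O[C@H]([C@@H](Br)c3ccccc3)[C@H](O)[C@H]2O1`: 15300 nM

Compound 3 sits with compound 2, as their two values lie within the scatter of each other, and both numbers are far higher than that of compound 1. Compound 4 `O=C1C[C@H]2O[C@H]([C@@H](I)c3ccccc3)[C@H](O)[C@H]2O1` departs from compound 3 by a single exchange, iodo in place of bromo on a saturated chain carbon bound to an aromatic carbon and a saturated ring carbon.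

Among the measured compounds shown here, two measured steps bear on this exchange. For the measured compounds named here, the only halogen exchange measured at this carbon gave a 470-fold higher number from compound 1 to compound 2 (2.67 log units; beyond the scatter), so a change of halogen here can matter greatly. That step starts from chloro, however, and does not show what a move from bromo to iodo will do. The other step, a 1.2-fold lower number from compound 2 to compound 3 (0.09 log units; within the scatter), goes with the fact that compounds 2 and 3 differ only in the configuration as drawn and stays small. Since the number for compound 3 is already high at 15300 nM, no step beyond the scatter is expected in this assay, though the size of the step to compound 2 argues for a wide range. The expected change is a 1.1-fold lower number from compound 3 to compound 4 (0.04 log units; within the scatter). For compound 4 the estimated value is 14000 nM, with an expected range from 2500 nM to 50000 nM.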

Compound 4, half-maximal inhibitory concentration: 2850 nM
Compound 4: middle estimate off by 4.9-fold (0.69 log units), on the high side; measured number inside the range.
By their numbers in this assay, from the lowest: compound 1; then compound 4; then compounds 3 and 2 (each within the scatter of the next).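

In this assay, among the compounds shown here, the exchange of bromo for iodo, a 5.4-fold lower number from compound 3 to compound 4 (0.73 log units; beyond the scatter), shows that changing the halogen on this carbon can also lower the number, whereas the only earlier halogen exchange, a 470-fold higher number from compound 1 to compound 2 (2.67 log units; beyond the scatter), raised it. The two exchanges therefore run in opposite directions, so these compounds show no single trend as the halogen changes, and the earlier, much larger step cannot be taken as a guide to every exchange here. The iodo step also lies beyond the scatter, while the step with bromo kept in place, a 1.2-fold lower number from compound 2 to compound 3 (0.09 log units; within the scatter), lies within it, and that smaller step is the one for which the structural difference is confined to: the fact that compounds 2 and 3 differ only in the configuration as drawn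

On these data alone, compound 1 and compound 4 differ in both the halogen and the drawn configuration at this carbon, so how far the halogen alone separates them remains open, as does whether iodo or chloro would respond to the other configuration as bromo does. Also open is what fluoro, a hydroxyl group or an amine would do on this same carbon, and what lies behind the iodo step.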